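The compounds below may be only part of what the source reports. "The series", "measured", "known", "first", "only" and "open" are said of these compounds alone.

Among the measured compounds shown here, in a functional assay on HCC 2998 cells (Homo sapiens) for antiproliferative activity (a higher number here means a weaker inhibitor of growth, a lower number a stronger inhibitor of growth), compound 1 `COc1ccc(-c2nc3cc(F)ccc3s2)cc1OC` gives 0.25 nM and holds the lower of the two numbers so far. Compound 2 `COc1cc(-c2nc3cc(F)ccc3s2)cc(O)c1OC` keeps the fluoro and gives 6490 nM with hydroxy in place of hydrogen on an aromatic carbon. This one measured step is a 26000-fold higher number from compound 1 to compound 2 (4.41 log units; beyond the scatter) and it is large. For the measured compounds named here, compound 3 `COc1ccc(-c2nc3cc(Br)ccc3s2)cc1OC` is still unmeasured and has bromo in place of fluoro on an aromatic carbon as its only change. Going by the values given here, no measured step touches the fluoro, so the hydroxy step bears only indirectly, showing that a single small change can move this number a long way. With compound 1 at 0.25 nM and so little data, a rise seems likelier than a fall, though its size is uncertain. The expected change is an 8.0-fold higher number from compound 1 to compound 3 (0.90 log units; beyond the scatter) in this assay as a rough estimate. For compound 3 the estimated value is 2 nM (expected range 0.1 nM to 100 nM).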

Compound 3, concentration for 50% growth inhibition: 20000 nM
Beside the measured number, compound 3's estimate is 10000-fold (4.00 log units) below it, and the stated range ends below it.
By their numbers in this assay, from the lowest: compound 1; then compound 2; then compound 3.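

Among the compounds shown here, the earlier step added a hydroxy and left the fluoro in place, whereas this is the first measured change at the fluoro position itself, and in this assay it is large: an 80000-fold higher number from compound 1 to compound 3 (4.90 log units; beyond the scatter). The swap trades one heavy atom for one heavy atom, with no ring, hydrogen-bond donor, hydrogen-bond acceptor or net charge entering or leaving, so these counts do not separate the two compounds, and even a change of one halogen for another matters greatly here. Nothing available explains why the number rises so far.

With only fluoro and bromo shown at this position, it remains open whether fluoro is specially favoured or bromo is specially harmful. Chloro, plain hydrogen or a methyl group on the same carbon would help to tell these two readings apart.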